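A few compounds are considered here, and "the series" means these few. Any claim that something is new, unique, unknown or untested is made for them only; others in the source may bear on it.

Of the compounds shown here, two from the same series have been measured so far. Compound 1 `Cc1c(Cc2cc(F)ccc2S(=O)(=O)c2ccccc2)c2c(n1CC(=O)O)CCNC2=O` and compound 2 `Cc1c(Cc2ccccc2S(=O)(=O)c2cccc(Cl)c2)c2c(n1CC(=O)O)CCNC2=O` share one core and differ only in their halogen substitution. In a functional assay on CHO.K1 cells for antagonist activity at prostaglandin D2 receptor 2 (Homo sapiens), read by GTPgammaS binding, with a stated time of 1 h (on this read-out lower numbers stand for stronger inhibition and higher numbers for weaker inhibition), compound 1 gives 3.7 nM. In this assay compound 2 gives 4 nM, the higher of the two numbers, though its gap to compound 1 lies within the scatter of repeated measurements, so the two cannot be told apart on these data. Compound 3 `Cc1c(Cc2ccccc2S(=O)(=O)c2ccc(Cl)cc2)c2c(n1CC(=O)O)CCNC2=O` has not yet been measured. It is built from compound 2 with the same atoms joined differently: 4-chlorophenyl in place of 3-chlorophenyl on a sulfonyl sulfur. For the measured compounds named here, no measured pair shows the same kind of move, so nothing here tells how much this swap weighs. Exchanging one chlorophenyl isomer for another while everything else stays fixed is the sort of step that often falls within the scatter, and a modest shift in either direction is about as likely as none. The step of a 1.3-fold higher number from compound 2 to compound 3 (0.10 log units; within the scatter) is therefore expected to be small. The estimate for compound 3 in this assay is 5 nM, expected to fall between 2 nM and 15 nM.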

Compound 3, half-maximal inhibitory concentration: 8.5 nM
Estimate against measurement, compound 3: 1.7-fold (0.23 log units) below; the measured number falls inside the stated range.
By their numbers in this assay, from the lowest: compounds 1 and 2 (each within the scatter of the next); then compound 3.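

For the compounds shown here, the swap of 3-chlorophenyl for 4-chlorophenyl on a sulfonyl sulfur gives the first single-place comparison, and in this assay it produces a 2.1-fold higher number from compound 2 to compound 3 (0.33 log units; beyond the scatter). Since compound 2 and compound 3 contain the same atoms joined differently, this pair shows that the read-out can respond to where the chlorine sits on this ring, not only to whether a chlorine is present; the higher number for compound 3 means weaker inhibition, but the step is modest and only just clears the usual scatter of repeated measurements. No independent measurement among the data explains why the 4-chlorophenyl group gives the higher number.

This single pair cannot show whether the same preference would hold for other groups on the ring, such as a 3-methoxyphenyl and 4-methoxyphenyl pair or a 3-bromophenyl and 4-bromophenyl pair. It also leaves open how either chlorophenyl group would compare with a pyridine ring on the same sulfonyl sulfur, or whether the step would keep its size with a fluorine on the other aromatic ring.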